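The source may hold more compounds than are shown below. What is called first, only, known or untested is meant among the compounds shown, and "the series" means these compounds.

Compound 1 `CNC(=O)[C@@H]1C[C@H](N2CCc3c(cccc3OCCc3ccccc3)C2)CN1C(=O)c1ccc(CN)c(OC)c1`: 3 nM
Compound 2 `CNC(=O)[C@@H]1C[C@H](N2CCc3c(cccc3OCCC3CC3)C2)CN1C(=O)c1ccc(CN)c(OC)c1`: 2 nM
Compound 3 `CNC(=O)[C@@H]1C[C@H](N2CCc3c(ncnc3OCCC3CC3)C2)CN1C(=O)c1ccc(CN)c(OC)c1`: 6 nM

All three were tested in an assay on isolated protein for inhibition of serine protease 1 (Homo sapiens), read by fluorescence; on this read-out higher numbers stand for weaker inhibition and lower numbers for stronger inhibition. Compound 1 and compound 2 share a core and differ by phenyl in place of cyclopropyl on a saturated chain carbon, two bonds along the chain from an oxygen on an aromatic ring; that change gave a 1.5-fold higher number from compound 2 to compound 1 (0.18 log units; within the scatter). Compound 3 carries a different core, and how its core differs from that of compound 2 is not broken down here. In this assay compound 3 gives 6 nM, a number beyond the usual scatter from that of compound 2 but within it of compound 1.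

Compound 4 `CNC(=O)[C@@H]1C[C@H](N2CCc3c(ncnc3OCCc3ccccc3)C2)CN1C(=O)c1ccc(CN)c(OC)c1` has not yet been measured. It differs from compound 3 by phenyl in place of cyclopropyl on a saturated chain carbon, two bonds along the chain from an oxygen on an aromatic ring, the same change seen between compound 2 and compound 1. Because that earlier change gave a 1.5-fold higher number from compound 2 to compound 1 (0.18 log units; within the scatter), the step expected for compound 4 is a 1.3-fold higher number from compound 3 to compound 4 (0.12 log units; within the scatter). Compound 4 is estimated to give 8 nM in this assay, expected to fall between 3 nM and 20 nM.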

Compound 4, half-maximal inhibitory concentration: 5 nM
For compound 4 the middle estimate is 1.6-fold (0.20 log units) above the measured one; the measured number falls inside the stated range.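

In this assay, putting phenyl in place of cyclopropyl on the second core gave a 1.2-fold lower number from compound 3 to compound 4 (0.08 log units; within the scatter). Set beside the same change on the first core, the two steps do not differ by more than repeat measurements would: the same change on two cores in this assay, a 1.5-fold higher number (0.18 log units; within the scatter) from compound 2 to compound 1 and a 1.2-fold lower number (0.08 log units; within the scatter) from compound 3 to compound 4, 1.8-fold (0.26 log units) apart, within the scatter of two such steps. On these two cores, then, the change leaves the number within the scatter each time, but two pairs cannot show that this would hold on further cores, nor can steps this small reveal a slight influence of the core.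

The compounds shown leave open what other groups at this place would do, such as an amine, a carboxylic acid or a longer chain, on either core.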